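Swapping halogens on the amide-linked phenyl ring

A few compounds are considered here, and "the series" means these few. Any claim that something is new, unique, unknown or untested is made for them only; others in the source may bear on it.

Compound 1 `CCN(C(=O)c1c(O)c2c(Br)cccc2n(C)c1=O)c1ccccc1`: 95%
Compound 2 `COc1cccc2c1c(O)c(C(=O)N(C)c1ccccc1F)c(=O)n2C`: 82%
Compound 3 `COc1cccc2c1c(O)c(C(=O)N(C)c1cc(F)ccc1F)c(=O)n2C`: 90%

These three compounds were tested in a functional assay on the whole organism for inhibition, with Mus musculus as the target, at a dose of 1 mg/kg by the oral route; on this read-out higher numbers stand for more inhibition at the one dose given (going by the name of the read-out) and lower numbers for less inhibition. Compound 3 lies close to both neighbours: its gap to compound 1 and its gap to compound 2 are each within the usual scatter of this assay, so the three numbers cannot be told apart with confidence.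

Compound 4 `COc1cccc2c1c(O)c(C(=O)N(C)c1cccc(Cl)c1)c(=O)n2C` has not yet been measured. It differs from compound 3 in one place: 3-chlorophenyl in place of 2,5-difluorophenyl on an amide-type nitrogen. Among the measured compounds shown here, no measured pair swaps one halogen pattern for another on that ring, so the only step that bears on it is the fluoro-for-hydrogen step, a number 8 percentage points higher from compound 2 to compound 3 (within the scatter), which stayed within the scatter. On that basis a small step is expected, a number 4 percentage points lower from compound 3 to compound 4 (within the scatter), with no direction beyond the scatter. Compound 4 is therefore estimated at 86%, with a range from 68% to 97%.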

Compound 4, a percentage reported as inhibition, in the whole organism at one dose (the size of the read-out at that dose, not a potency): 85%
For compound 4 the middle estimate is 1 percentage points above the measured one, and the stated range covers the measured number.
By their numbers in this assay, from the lowest: compounds 2, 4, 3 and 1 (each within the scatter of the next, the first and the last beyond it).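

Among the compounds shown here, compound 4 brings the first swap of one halogen pattern for another on the amide-type nitrogen, and in this assay the change gives a number 5 percentage points lower from compound 3 to compound 4 (within the scatter) and a number 3 percentage points higher from compound 2 to compound 4 (within the scatter) when set against the two fluorinated compounds. Neither 2,5-difluorophenyl nor 2-fluorophenyl can therefore be told apart from 3-chlorophenyl here, so among these three compounds the kind and number of halogens on this ring make no readable difference. No other measurement is available to account for these numbers.

As far as these compounds go, every ring compared here carries only halogen, so it remains open whether an amine or a carboxylic acid on the phenyl ring would keep the read-out at this level. Also open, from the compounds shown here alone, is whether the phenyl ring is needed at all, for instance whether a saturated cyclohexyl ring could stand in its place.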